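A few compounds are considered here, and "the series" means these few. Any claim that something is new, unique, unknown or untested is made for them only; others in the source may bear on it.

Compound 3 `COC(=O)C1=C(C)NC(C)=C(C(=O)OCCCl)C1c1cccc([N+](=O)[O-])c1` gives the lowest number of the three measured compounds in a functional assay on HEK293 cells for antagonist activity at Voltage-dependent L-type calcium channel subunit alpha-1D (Rattus norvegicus), read by FLIPR (a lower number here means a stronger inhibitor, a higher number a weaker inhibitor), at 22 nM. Compound 1 `CCCC1=C(C(=O)OCC)C(c2cccc([N+](=O)[O-])c2)C(C(=O)OCC)=C(C)N1` stands nearest to it with 105 nM in this assay, and compound 2 `CCOC(=O)C1=C(C)NC(/C=C/c2ccc([N+](=O)[O-])cc2)=C(C(=O)OCC)C1c1cccc([N+](=O)[O-])c1` stands furthest with 2060 nM. The one measured step that joins two of these compounds is a 20-fold higher number from compound 1 to compound 2 (1.29 log units; beyond the scatter), which sits on a double-bonded ring carbon of the shared core.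

Compound 4 `COC(=O)C1=C(C)NC(C)=C(C(=O)OCCCCc2ccc(OC)cc2)C1c1cccc([N+](=O)[O-])c1` is not yet measured. It differs from compound 3 by 2-(4-methoxyphenyl)ethyl in place of chloro on a saturated chain carbon, two bonds along the chain from an oxygen next to a carbonyl group, so the change lies on the ester chain and not on the ring carbon that the step from compound 1 to compound 2 concerns. That step therefore bears on the present one only loosely: it shows that a large group entering at one place can raise the number strongly, but it does not speak to the chain where the new group enters here. Among the measured compounds shown here, no measured pair tells how this assay answers a change on that chain, so the expectation must stay wide. He expects compound 4 to show a step of a 1.8-fold higher number from compound 3 to compound 4 (0.26 log units; within the scatter) in this assay, a modest rise that may well fall within the scatter. His estimate for compound 4 is 40 nM, with a range from 10 nM to 160 nM.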

Compound 4, half-maximal inhibitory concentration: 38 nM
For compound 4 the middle estimate is 1.1-fold (0.02 log units) above the measured one; measured number inside the range.
By their numbers in this assay, from the lowest: compounds 3 and 4 (each within the scatter of the next); then compound 1; then compound 2.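

The ester chain gives the first measured answer here: in this assay, 2-(4-methoxyphenyl)ethyl in place of chloro gives a 1.7-fold higher number from compound 3 to compound 4 (0.24 log units; within the scatter). At this place on a saturated chain carbon, two bonds along the chain from an oxygen next to a carbonyl group, the 10 heavy atoms and the six-membered aromatic ring that enter leave compound 4 within the scatter of compound 3, so the assay does not separate the two. The earlier step, with a group entering on a double-bonded ring carbon, was a 20-fold higher number from compound 1 to compound 2 (1.29 log units; beyond the scatter), so across these two steps a large entering group goes with a large step at one place and not at the other, and nothing available accounts for that contrast.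

The compounds shown leave open which part of 2-(4-methoxyphenyl)ethyl matters on this chain, as no compound here carries a plain phenyl ring or a shorter or longer chain to the ring. They also leave open whether an amine or a carboxylic acid in place of chloro on the same chain carbon would stay within the scatter of compound 3.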